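The source may hold more compounds than are shown below. What is called first, only, known or untested is meant among the compounds shown, and "the series" means these compounds.

The measured compounds and their values:

Compound 1, `COc1ccc(C(=O)CSc2nc3c([nH]2)c(=O)n(C)c(=O)n3C)cc1`: 8100 nM
Compound 2, `Cn1c(=O)c2[nH]c(SCC(=O)c3ccc(Cl)cc3)nc2n(C)c1=O`: 9900 nM
Compound 3, `COc1ccc(C(=O)CSc2nc3[nH]c(=O)n(C)c(=O)c3[nH]2)cc1`: 6700 nM

These three compounds were tested in a functional assay on HT-29 cells (Homo sapiens) for inhibition, read by MTT assay, with a stated time of 48 h; on this read-out higher numbers stand for weaker inhibition and lower numbers for stronger inhibition. Compound 1 and compound 2 share one core and differ only in the substituent on the phenyl ring: chloro in place of methoxy on an aromatic carbon. This change gave a 1.2-fold higher number from compound 1 to compound 2 (0.09 log units; within the scatter). Compound 3 carries the same 4-methoxyphenyl group as compound 1 but differs in the core: hydrogen in place of methyl on an aromatic nitrogen. That change gave a 1.2-fold lower number from compound 1 to compound 3 (0.08 log units; within the scatter). All three values lie within the usual scatter of one another, so no ordering among them is claimed.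

Compound 4, `Cn1c(=O)[nH]c2nc(SCC(=O)c3ccc(Cl)cc3)[nH]c2c1=O`, has not yet been measured in this assay. It stands to compound 3 as compound 2 stands to compound 1: chloro in place of methoxy on an aromatic carbon. The place of the change is described in the same words in both pairs, so this is taken to be the same change, made on the core of compound 3 rather than on the core of compound 1. Among the compounds with values here, because the only measured example of this change gave a 1.2-fold higher number from compound 1 to compound 2 (0.09 log units; within the scatter), the step for compound 4 is expected to be small, a 1.2-fold higher number from compound 3 to compound 4 (0.08 log units; within the scatter), resting on that single pair and on the value of compound 3, 6700 nM. On that basis compound 4 is estimated to give 8000 nM in this assay, with a likely range from 4000 nM to 16000 nM.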

Compound 4, half-maximal inhibitory concentration: 7200 nM
Compound 4: the middle estimate sits 1.1-fold (0.05 log units) above what was measured, and the stated range covers the measured number.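

In this assay, the move from 4-methoxyphenyl to 4-chlorophenyl on the core of compound 3 gave a 1.1-fold higher number from compound 3 to compound 4 (0.03 log units; within the scatter), and this step agrees with the one seen earlier on the other core: the same change on two cores in this assay, a 1.2-fold higher number (0.09 log units; within the scatter) from compound 1 to compound 2 and a 1.1-fold higher number (0.03 log units; within the scatter) from compound 3 to compound 4, 1.1-fold (0.06 log units) apart, within the scatter of two such steps. Hydrogen in place of methyl on an aromatic nitrogen, now read with the 4-chlorophenyl group in place, gave a 1.4-fold lower number from compound 2 to compound 4 (0.14 log units; within the scatter), and this step likewise agrees with its earlier counterpart: the same change on two cores in this assay, a 1.2-fold lower number (0.08 log units; within the scatter) from compound 1 to compound 3 and a 1.4-fold lower number (0.14 log units; within the scatter) from compound 2 to compound 4, 1.1-fold (0.06 log units) apart, within the scatter of two such steps. Within the data shown here, each change therefore behaves alike on the two cores, but every step involved lies within the scatter, so this shows only that neither change produced a step that could be told from scatter on these four compounds, not that a step of real size would carry over from one core to another.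

The compounds shown carry only methoxy or chloro on the phenyl ring, which leaves open whether an amine or a carboxylic acid there, or a longer chain in place of the one linking the ring to the sulfur, would give a step beyond the scatter. They also leave open whether these two changes would behave alike on any cell line other than the one tested here.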